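A cyanophenyl in place of a fluorophenyl on the boron core

The source may report more compounds than this note shows. Statements on the series, on what has been measured and on what is new or still open speak of the compounds shown alone.

Of the compounds shown here, three sharing one core have been tested in an ADME assay on WI-38 cells (Homo sapiens) for cytotoxicity, read by MTT assay, with a stated time of 72 h; a lower number here means a stronger inhibitor, a higher number a weaker inhibitor. Compound 1 `C#Cc1ccc(NC(=O)CCc2cccc3c2B(O)OC3)cc1` reaches only the limit of the assay, > 100000 nM, so no number is known for it; (the limit of > 100000 nM in this assay, at which 1 of the 3 values shown sits). Compound 2 `O=C(CCc1cccc2c1B(O)OC2)Nc1cccc(-c2ccc(F)cc2)c1` gives 4100 nM, the lowest of the two numbers measured, while compound 3 `O=C(CCc1cccc2c1B(O)OC2)Nc1cccc(-c2ccc(OC(F)(F)F)cc2)c1` gives 25000 nM. For the measured compounds named here, the one measured step, a 6.1-fold higher number from compound 2 to compound 3 (0.79 log units; beyond the scatter), exchanges the substituent on the outer ring and weakens the effect on the cells modestly.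

Compound 4 `N#Cc1cccc(-c2cccc(NC(=O)CCc3cccc4c3B(O)OC4)c2)c1` differs from compound 2 by 3-cyanophenyl in place of 4-fluorophenyl on an aromatic carbon. Going by the values given here, no measured step matches this change exactly; the step from compound 2 to compound 3 shows that altering the group on the outer ring can shift the number, but its direction for a nitrile is not known from these data. A small weakening, or no change beyond the scatter, is therefore expected, as a 2.0-fold higher number from compound 2 to compound 4 (0.29 log units; within the scatter). Compound 4 is estimated at 8000 nM, with a range from 2500 nM to 30000 nM.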

Compound 4, half-maximal inhibitory concentration: 7300 nM
Compound 4: middle estimate off by 1.1-fold (0.04 log units), on the high side; the measured number falls inside the stated range.
By their numbers in this assay, from the lowest: compounds 2 and 4 (each within the scatter of the next); then compound 3. At a limit, above all of these: compound 1.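

In this assay the new step reads a 1.8-fold higher number from compound 2 to compound 4 (0.25 log units; within the scatter), so the numbers for 3-cyanophenyl and 4-fluorophenyl at this place cannot be told apart. For the compounds shown here, this shows that a nitrile-bearing outer ring can stand here without a shift beyond the usual scatter, which the earlier compounds could not show. Going by these compounds alone, the only step beyond the scatter remains the trifluoromethoxy exchange, a 6.1-fold higher number from compound 2 to compound 3 (0.79 log units; beyond the scatter), and nothing measured here accounts for the difference between the two steps.

This exchange alters both the group on the outer ring and where it sits, so the compounds shown do not separate those two effects; 4-cyanophenyl or 3-fluorophenyl would help to do so. As far as these compounds go, whether an outer ring carrying an amine or a carboxylic acid would give a similar number also remains open.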